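The source may hold more compounds than are shown below. What is called first, only, known or untested is meant among the compounds shown, and "the series" means these compounds.

Measured so far:
compound 1 `CCOC(=O)COCc1cc(-c2cc(Br)ccc2OC)no1` — > 200000 nM
compound 2 `C=CCOCc1cc(-c2cc(Br)ccc2OC)no1` — 90400 nM
compound 3 `C=CCc1ccc(OC)c(-c2cc(CN3CCN(CC(=O)OCC)CC3)on2)c1` — > 200000 nM

In a functional assay on BV-2 cells (Mus musculus) for inhibition, read by Griess assay, with a stated time of 24 h (on this read-out higher numbers stand for weaker inhibition and lower numbers for stronger inhibition), compound 1 gives > 200000 nM, which is a limit of the assay and not a number. Compound 3 gives > 200000 nM, again only a limit. Compound 2 gives 90400 nM. The change vinyl in place of ethoxycarbonyl on a saturated chain carbon bound to an oxygen on a saturated carbon made a step of an at least 2.2-fold lower number from compound 1 to compound 2 (0.34 log units; beyond the scatter); its size can only be given as a bound because of the limit of > 200000 nM in this assay, at which 2 of the 3 values shown sit. The difference between the core of compound 1 and the core of compound 3 is not broken down here.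

Compound 4 `C=CCc1ccc(OC)c(-c2cc(CN3CCN(CC=C)CC3)on2)c1` arises from compound 3 by vinyl in place of ethoxycarbonyl on a saturated chain carbon bound to an amine nitrogen in a ring. This is the same kind of change as before, though the place differs: in the earlier pair the chain carbon is bound to an oxygen on a saturated carbon, here it is bound to an amine nitrogen in a ring. The expected step, beside the earlier at least 2.2-fold lower number from compound 1 to compound 2 (0.34 log units; beyond the scatter), is an at least 1.6-fold lower number from compound 3 to compound 4 (0.22 log units; that floor lies within the scatter), resting on what that one measured pair showed. Compound 4 is therefore estimated at 120000 nM, with a range from 40000 nM to 400000 nM.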

Compound 4, half-maximal inhibitory concentration: 111000 nM
Compound 4: middle estimate off by 1.1-fold (0.03 log units), on the high side; measured number inside the range.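

In this assay, vinyl in place of ethoxycarbonyl on the core of compound 3 gives an at least 1.8-fold lower number from compound 3 to compound 4 (0.25 log units; that floor lies within the scatter). Both pairs shown move towards a lower number, although only the earlier floor lies beyond the scatter, and their sizes cannot be set against each other: the same change on two cores in this assay, an at least 2.2-fold lower number (0.34 log units; beyond the scatter) from compound 1 to compound 2 and an at least 1.8-fold lower number (0.25 log units; that floor lies within the scatter) from compound 3 to compound 4; the limit leaves it open whether they differ Compound 3 gives > 200000 nM, which is a limit of the assay and not a number, so this pair fixes only a floor for the step and shows neither that the change carries over with the same size nor that it would hold on any further core.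

The compounds shown leave open whether the step depends on the double bond of the entering group or on the loss of the ester, which a saturated propyl chain or a longer chain in the same place could separate. They also leave open how a carboxylic acid or an amide there would read out on either core.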